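The source may report more compounds than this note shows. Statements on the series, on what has been measured and on what is new or still open speak of the compounds shown alone.

Measured so far in a functional assay on the whole organism (strain Wistar) for inhibition, with Rattus norvegicus as the target, read by paw edema, with a stated time of 4 h, at a dose of 100 mg/kg; a higher number here means more inhibition at the dose given (going by the name of the read-out), a lower number less inhibition:
compound 1 `COc1cc2c(cc1OC)C(CC(=O)Nc1cccc(Cl)c1)CC2`: 25.8%
compound 2 `COc1ccccc1NC(=O)CC1CCc2cc(OC)c(OC)cc21`: 23.4%

Compound 2 and compound 1 lie within the scatter of each other, the difference being a number 2.4 percentage points lower from compound 1 to compound 2 (within the scatter); no order between the two can be read from this assay.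

Compound 3 `COc1cc2c(cc1OC)C(CC(=O)Nc1cccnc1)CC2` is not yet measured. It differs from compound 2 by pyridin-3-yl in place of 2-methoxyphenyl on an amide-type nitrogen. Among the measured compounds shown here, the only measured step that bears on this, an exchange of the aryl group on the same amide-type nitrogen, is a number 2.4 percentage points lower from compound 1 to compound 2 (within the scatter), within the scatter. A step of a number 0.6 percentage points higher from compound 2 to compound 3 (within the scatter) is therefore expected, none beyond the scatter. Compound 3 is estimated at 24%, between 10% and 40%.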

Compound 3, a percentage reported as inhibition, in the whole organism at one dose (the size of the read-out at that dose, not a potency): 34.4%
The estimate for compound 3 lay 10.4 percentage points below the measured number, and the stated range covers the measured number.
By their numbers in this assay, from the lowest: compounds 2, 1 and 3 (each within the scatter of the next, the first and the last beyond it).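

In this assay, this position on the amide-type nitrogen now shows a step beyond the scatter, with pyridin-3-yl in place of 2-methoxyphenyl: a number 11 percentage points higher from compound 2 to compound 3 (beyond the scatter). With pyridin-3-yl in place of 3-chlorophenyl, the step stays within the scatter: a number 8.6 percentage points higher from compound 1 to compound 3 (within the scatter). So the exchange to pyridin-3-yl clears the scatter against only one of the two aryl groups, and no supporting data explain the difference.

Still open, on these data alone, is how pyridin-2-yl or pyridin-4-yl would compare with pyridin-3-yl on this nitrogen. As far as these compounds go, a phenyl ring carrying an amine or a carboxylic acid also remains untested in these compounds.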